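Three Anilino Analogues and an Untested Dimethylphenyl Variant

The source may report more compounds than this note shows. Statements on the series, on what has been measured and on what is new or still open speak of the compounds shown alone.

Of the compounds shown here, three sharing one core have been measured in a functional assay on ECa-109 cells for inhibition, with ECa-109 cell line (Homo sapiens) as the target, read by sulforhodamine B assay; on this read-out lower numbers stand for stronger inhibition and higher numbers for weaker inhibition. Compound 1 `O=C1C(Nc2ccc(I)cc2)=CC(=O)c2c1nc1n2[C@H]2OC[C@@H](O)[C@H]2OC1` carries an iodo group on its aromatic ring and gives 2530 nM. Compound 2 `O=C1C=C(Nc2ccccc2F)C(=O)c2c1nc1n2[C@H]2OC[C@@H](O)[C@H]2OC1` bears a 2-fluorophenyl on the amine nitrogen and gives 2760 nM. Among the measured compounds shown here, compound 3 `O=C1C(Nc2ccc(C(F)(F)F)cc2)=CC(=O)c2c1nc1n2[C@H]2OC[C@@H](O)[C@H]2OC1` carries trifluoromethyl in place of iodo and gives 2250 nM; the only single-point step among them, a 1.1-fold lower number from compound 1 to compound 3 (0.05 log units; within the scatter), is within the scatter. The number for compound 2 is nominally the highest of the three, yet its gaps to compound 1 and to compound 3 are both within the scatter, so the three compounds cannot be told apart in this assay.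

Compound 4 `Cc1ccc(NC2=CC(=O)c3nc4n(c3C2=O)[C@H]2OC[C@@H](O)[C@H]2OC4)cc1C` has not been measured. It differs from compound 2 by 3,4-dimethylphenyl in place of 2-fluorophenyl on an amine nitrogen. For the measured compounds named here, no measured step touches the amine nitrogen or involves a dimethyl pattern, and the one step that is known, from compound 1 to compound 3, stayed within the scatter. The record thus gives no ground for expecting a move beyond the scatter in this assay, in either direction.

Compound 4 is therefore expected to give about 2600 nM, in the range 1200 nM to 5600 nM. The step this estimate implies is a 1.1-fold lower number from compound 2 to compound 4 (0.03 log units; within the scatter), expected to lie within the scatter.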

Compound 4, half-maximal inhibitory concentration: 2820 nM
The estimate for compound 4 lay 1.1-fold (0.04 log units) below the measured number; measured number inside the range.
By their numbers in this assay, from the lowest: compounds 3, 1, 2 and 4 (each within the scatter of the next).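

Among the compounds shown here, this is the first step read at the amine nitrogen itself: a 1.0-fold higher number from compound 2 to compound 4 (0.01 log units; within the scatter) in this assay, within the scatter, so compound 2 and compound 4 cannot be told apart. The earlier compounds shown here offered only a step between two groups on the ring of the aniline, whereas this one exchanges the whole aryl group on that nitrogen, 2-fluorophenyl for 3,4-dimethylphenyl, and the read-out still does not separate the pair. It thus shows that at this position, a fluorine-bearing phenyl and a dimethyl-bearing phenyl are equivalent within the resolution of this assay, though no information is available on why that should be so.

On these data alone, whether anything other than a substituted phenyl on the amine nitrogen, such as a benzyl group, a cyclohexyl group or a longer alkyl chain, or a phenyl ring bearing a carboxylic acid or an amine, would move the number beyond the scatter remains open. Every compound shown also keeps the hydroxyl on the shared core, so what a methoxy group or an amine in its place would do is open as well.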